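This account rests on a few compounds, and the source may have more. Where it says the series, first, only, none or still open, it means among the compounds named here.

In an ADME assay on MT4 cells (Homo sapiens) for cytotoxicity, read by MTT assay, with a stated time of 5 days (a lower number here means that less compound is tolerated, a higher number that more compound is tolerated), compound 3 `Cc1cc(C#N)cc(C)c1Oc1nc(Nc2ccc(C#N)cc2)ncc1-c1ccoc1` gives 4980 nM, the lowest of the three numbers here. Compound 1 `Cc1cc(C#N)cc(C)c1Oc1nc(Nc2ccc(C#N)cc2)ncc1-c1ccccc1` gives 31800 nM, and compound 2 `Cc1cc(C)cc(-c2cnc(Nc3ccc(C#N)cc3)nc2Oc2c(C)cc(C#N)cc2C)c1` gives 39000 nM. Compound 4 `Cc1cc(C#N)cc(C)c1Oc1nc(Nc2ccc(C#N)cc2)ncc1-c1ccc(Cl)cc1` differs from compound 3 by 4-chlorophenyl in place of furan-3-yl on an aromatic carbon. Among the compounds with values here, the steps that bear on this are a 6.4-fold lower number from compound 1 to compound 3 (0.81 log units; beyond the scatter) and a 7.8-fold lower number from compound 2 to compound 3 (0.89 log units; beyond the scatter), both of which ran toward the lower number when furan-3-yl entered in place of phenyl or 3,5-dimethylphenyl. The change to compound 4 goes the other way, so for compound 4 the expected step is a 6.0-fold higher number from compound 3 to compound 4 (0.78 log units; beyond the scatter), a rise beyond the scatter back toward the numbers of the two phenyl-bearing compounds. Compound 4 is therefore estimated at 30000 nM, with a range from 12000 nM to 70000 nM.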

Compound 4, half-maximal cytotoxic concentration: 72600 nM
For compound 4 the middle estimate is 2.4-fold (0.38 log units) below the measured one; measured number above the stated range.
By their numbers in this assay, from the lowest: compound 3; then compounds 1, 2 and 4 (each within the scatter of the next, the first and the last beyond it).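

In this assay a single chloro added to the phenyl group moves the number beyond the scatter (a 2.3-fold higher number from compound 1 to compound 4 (0.36 log units; beyond the scatter)), so this position responds to a small change on that ring, not only to a change of ring type. The change from furan-3-yl to 4-chlorophenyl gives a large step (a 15-fold higher number from compound 3 to compound 4 (1.16 log units; beyond the scatter)), while the other step among the substituted phenyl groups stays within the scatter (a 1.9-fold higher number from compound 2 to compound 4 (0.27 log units; within the scatter)). Nothing measured here explains these steps. Still open, on these data alone, is what an amine or a carboxylic acid on the phenyl ring would give.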